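This account rests on a few compounds, and the source may have more. Where it says the series, first, only, none or still open, it means among the compounds named here.

Measured compounds:
compound 1 `COc1c(N2CC[C@@H](CN)C2)c(F)cc2c(=O)c(C(=O)O)cn(Cc3ccc(-c4ccccc4)cc3)c12`, 26000 nM in an assay on isolated protein for inhibition of DNA topoisomerase 1 (Homo sapiens), with a stated time of 15 min; a lower number here means a stronger inhibitor, a higher number a weaker inhibitor
compound 2 `COc1c(N2CC[C@@H](CN)C2)c(F)cc2c(=O)c(C(=O)O)cn(Cc3ccc(-n4cccn4)cc3)c12`, > 200000 nM in this assay, a limit of the assay
compound 3 `O=C(O)c1cn(Cc2ccc(-n3cccn3)cc2)c2cc(NC[C@H]3CCNC3)c(F)cc2c1=O`, 187000 nM in this assay

Compound 2 sits at a limit (the limit of > 200000 nM in this assay, at which 1 of the 3 values shown sits). The change from compound 2 to compound 1 is phenyl in place of 1H-pyrazol-1-yl on an aromatic carbon, and it gave an at least 7.6-fold lower number from compound 2 to compound 1 (0.88 log units; beyond the scatter). Compound 4 `O=C(O)c1cn(Cc2ccc(-c3ccccc3)cc2)c2cc(NC[C@H]3CCNC3)c(F)cc2c1=O` is not yet measured. It differs from compound 3 by phenyl in place of 1H-pyrazol-1-yl on an aromatic carbon, the same change, at the same place. How the core of compound 3 differs from the core of compound 2 is not broken down here.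

For compound 4 a step of a 7.5-fold lower number from compound 3 to compound 4 (0.87 log units; beyond the scatter) is expected in this assay, resting on the step of compound 2 to compound 1 an at least 7.6-fold lower number from compound 2 to compound 1 (0.88 log units; beyond the scatter) and on compound 3 at 187000 nM. Compound 4 is estimated at 25000 nM, with a likely range of 8000 nM to 80000 nM.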

Compound 4, half-maximal inhibitory concentration: 100000 nM
Compound 4: the middle estimate sits 4.0-fold (0.60 log units) below what was measured, outside the stated range (above it).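

On the core of compound 3, phenyl in place of 1H-pyrazol-1-yl gave a 1.9-fold lower number from compound 3 to compound 4 (0.27 log units; within the scatter). The change therefore does not carry over at one size between these two cores: the same change on two cores in this assay, an at least 7.6-fold lower number (0.88 log units; beyond the scatter) from compound 2 to compound 1 and a 1.9-fold lower number (0.27 log units; within the scatter) from compound 3 to compound 4, at least 4.1-fold (0.61 log units) apart, beyond the scatter of two such steps

Compound 2 gives > 200000 nM, which is a limit of the assay and not a number, so the earlier step has no fixed size: the limit of > 200000 nM in this assay, at which 1 of the 4 values shown sits.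

Going by these compounds, with one pair on each core, it remains open which part of the core difference, the methoxy group or the amine side chain, goes with the gap between the steps. Also open, on these data alone, is whether a pyridine ring in place of phenyl, or an amide in place of the carboxylic acid, would follow either step in this assay.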